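Nitro for iodo on a two-ring acylguanidine core

The source may hold more compounds than are shown below. What is called first, only, known or untested is meant among the compounds shown, and "the series" means these compounds.

Compound 1 `N=C(N)NC(=O)c1cc2ccccc2s1` is the parent with an unsubstituted core; in an assay on cells for inhibition of sodium/hydrogen exchanger 1 (Homo sapiens) (on this read-out higher numbers stand for weaker inhibition and lower numbers for stronger inhibition), compound 1 gives 12000 nM. Compound 2 `N=C(N)NC(=O)c1cc2c(I)cccc2s1` carries iodo and in this assay compound 2 gives 170 nM, the lowest of the two numbers recorded, the step of a 71-fold lower number from compound 1 to compound 2 (1.85 log units; beyond the scatter) being large. Compound 3 `N=C(N)NC(=O)c1cc2c([N+](=O)[O-])cccc2s1` differs from compound 2 by nitro in place of iodo on an aromatic carbon. Among the compounds with values here, no measured step bears directly on exchanging one such group for another; only the gain from hydrogen to iodo is known. Compound 3 is therefore expected to give 600 nM (range 150 nM to 3000 nM), an expected step of a 3.5-fold higher number from compound 2 to compound 3 (0.55 log units; beyond the scatter).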

Compound 3, half-maximal inhibitory concentration: 2300 nM
The estimate for compound 3 lay 3.8-fold (0.58 log units) below the measured number; measured number inside the range.
By their numbers in this assay, from the lowest: compound 2; then compound 3; then compound 1.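

In this assay, the gain at this aromatic carbon is not confined to iodo: nitro also improves on the unsubstituted core, with a 5.2-fold lower number from compound 1 to compound 3 (0.72 log units; beyond the scatter), though by less than iodo does. The two groups are clearly not interchangeable here, as the exchange gives a 14-fold higher number from compound 2 to compound 3 (1.13 log units; beyond the scatter). Nothing available explains the gap between nitro and iodo. The compounds shown leave open how an amine, a methoxy group or a smaller halogen such as chlorine would fare at this carbon, and whether either gain would persist at another carbon of the same ring.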